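Antiproliferative series: dimethylamino to pyrrolidin-1-yl on the propyl chain

This account rests on a few compounds, and the source may have more. Where it says the series, first, only, none or still open, it means among the compounds named here.

Measured in a functional assay on K562 cells (Homo sapiens) for antiproliferative activity, read by MTT assay, with a stated time of 48 h; a higher number here means a weaker inhibitor, a lower number a stronger inhibitor:
- compound 1 `COc1ccc(N2CCN(Cc3ccc4c(c3O)-c3ccc(cc3O)CCc3ccc(O)c(c3)Oc3ccc(cc3)CC4)CC2)cc1`: > 20000 nM (a limit of the assay, not a number)
- compound 2 `CN(C)c1cc2cc(c1O)Oc1ccc(cc1)CCc1cccc(O)c1-c1ccc(cc1O)CC2`: > 20000 nM (a limit of the assay, not a number)
- compound 3 `CN(C)CCCOc1cccc2c1-c1ccc(cc1O)CCc1ccc(O)c(c1)Oc1ccc(cc1)CC2`: 2610 nM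

Of these three compounds, only compound 3 has an actual number. In this assay compound 3 gives 2610 nM, and this is the one reference point for what follows. Compound 1 and compound 2 report only a limit.

Next in line is compound 4 `Oc1ccc2cc1Oc1ccc(cc1)CCc1cccc(OCCCN3CCCC3)c1-c1ccc(cc1O)CC2`. It keeps the shared core of compound 3 and carries pyrrolidin-1-yl in place of dimethylamino on a saturated chain carbon, three bonds along the chain from an oxygen on an aromatic ring. Put another way, 3-(dimethylamino)propyl becomes 3-(pyrrolidin-1-yl)propyl.

Going by the values given here, no two measured compounds differ in one place, so the series gives no direct precedent for this change. The working expectation is therefore no shift beyond the scatter in this assay, in either direction. The estimated change is a 1.0-fold lower number from compound 3 to compound 4 (0.02 log units; within the scatter), which is expected to stay within the scatter. The estimate for compound 4 is 2500 nM, with an expected range of 1000 nM to 6500 nM.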

Compound 4, half-maximal inhibitory concentration: 2940 nM
For compound 4 the middle estimate is 1.2-fold (0.07 log units) below the measured one, and the stated range covers the measured number.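

Going by these compounds alone, the step in this assay is a 1.1-fold higher number from compound 3 to compound 4 (0.05 log units; within the scatter) and it is the first single-place comparison the series offers. At this place, on a saturated chain carbon, three bonds along the chain from an oxygen on an aromatic ring, 3-(pyrrolidin-1-yl)propyl stands in for 3-(dimethylamino)propyl with no shift beyond the scatter, so the larger group with its five-membered non-aromatic ring leaves the read-out where it was. Nothing measured among the compounds shown bears on why the step is this small.

On these data alone, only these two amines are compared at this place, so it remains open whether piperidin-1-yl, morpholin-4-yl, a primary amine or a carboxylic acid at the end of the chain, or a longer chain carrying the same pyrrolidin-1-yl, would hold the number or move it. Compound 1 and compound 2 report only a limit of the assay and give no step to this pair: the limit of > 20000 nM in this assay, at which 2 of the 4 values shown sit.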